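From dimethylphenyl to difluorophenyl on the amide nitrogen

The source may hold more compounds than are shown below. What is called first, only, known or untested is meant among the compounds shown, and "the series" means these compounds.

Compound 3 `CCN1CCc2c(c(C(C)(C)C)nn2C(=O)Nc2ccc(C)cc2C)C1` gives 59.9% in a functional assay on the whole organism (strain Swiss albino) for inhibition, with Mus musculus as the target, in the formalin test, with a stated time of 30 min, at a dose of 100 mg/kg; on this read-out higher numbers stand for more inhibition at the one dose given (going by the name of the read-out) and lower numbers for less inhibition. It stands second highest of the three compounds measured: compound 1 `CCN1CCc2c(c(C(C)(C)C)nn2C(=O)Nc2c(C)cccc2C)C1` gives 68%, and the step of a number 8.1 percentage points lower from compound 1 to compound 3 (within the scatter) lies within the scatter, while compound 2 `CCN1CCc2c(c(C(C)(C)C)nn2C(=O)Nc2cc(C)ccc2C)C1` gives 15.7% and the step of a number 44.2 percentage points higher from compound 2 to compound 3 (beyond the scatter) lies beyond it. Compound 4 `CCN1CCc2c(c(C(C)(C)C)nn2C(=O)Nc2ccc(F)cc2F)C1` differs from compound 3 in one place: 2,4-difluorophenyl in place of 2,4-dimethylphenyl on an amide-type nitrogen. Among the measured compounds shown here, the measured steps only move a methyl group around the ring, as in a number 52.3 percentage points lower from compound 1 to compound 2 (beyond the scatter); none exchanges methyl for fluorine, so no step bears directly on this change. The estimate for compound 4 therefore rests on compound 3 alone, with a wide range. Compound 4 is expected to give 45%, between 15% and 70%. The expected step of a number 14.9 percentage points lower from compound 3 to compound 4 (beyond the scatter) is thus modest and uncertain in direction.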

Compound 4, a percentage reported as inhibition, in the whole organism at one dose (the size of the read-out at that dose, not a potency): 73.4%
Compound 4: the middle estimate sits 28.4 percentage points below what was measured; the measured number lies above the stated range.
By their numbers in this assay, from the lowest: compound 2; then compounds 3, 1 and 4 (each within the scatter of the next, the first and the last beyond it).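

Unlike the earlier steps, which only move methyl groups around the ring, this one exchanges them for fluorine, and in this assay that exchange gives a number 13.5 percentage points higher from compound 3 to compound 4 (beyond the scatter), so inhibition at this position survives the loss of both methyl groups. Against the other two dimethylphenyl groups, the 2,4-difluorophenyl group gives a number 5.4 percentage points higher from compound 1 to compound 4 (within the scatter) and a number 57.7 percentage points higher from compound 2 to compound 4 (beyond the scatter). Nothing given here explains the rise. The compounds shown leave open whether moving the fluorines matters as much as moving the methyl groups did, and whether chlorine atoms or methoxy groups on this phenyl ring would read like fluorine.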